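Ethoxy in place of bromo: compound 3 to compound 4

A few compounds are considered here, and "the series" means these few. Any claim that something is new, unique, unknown or untested is made for them only; others in the source may bear on it.

Values in a functional assay on B16-F10 cells (Mus musculus) for antiproliferative activity, read by MTT assay, with a stated time of 48 h; on this read-out lower numbers stand for stronger inhibition and higher numbers for weaker inhibition:
Compound 1 `CCCCOc1ccc(C(=O)/C=C/c2c(/C=C/c3ccc(OC)cc3)cc(OC)cc2OC)cc1`: 5.3 ug/mL
Compound 2 `CCCCCCOc1ccc(C(=O)/C=C/c2c(/C=C/c3ccc(OC)cc3)cc(OC)cc2OC)cc1`: 10.4 ug/mL
Compound 3 `COc1ccc(/C=C/c2cc(OC)cc(OC)c2/C=C/C(=O)c2ccc(Br)cc2)cc1`: 6.5 ug/mL

The three measured values lie within the scatter of one another, so compound 3 is not separated from either of the others. The two steps that reach it are a 1.2-fold higher number from compound 1 to compound 3 (0.09 log units; within the scatter) and a 1.6-fold lower number from compound 2 to compound 3 (0.20 log units; within the scatter).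

The next compound is compound 4 `CCOc1ccc(C(=O)/C=C/c2c(/C=C/c3ccc(OC)cc3)cc(OC)cc2OC)cc1`. It carries ethoxy in place of bromo on an aromatic carbon, para to a large group: ethoxy in place of bromo on an aromatic carbon. Those two steps bear most directly on this change, since each exchanges an alkoxy group for bromo at this place, and neither goes beyond the scatter. The chain-length step, a 2.0-fold higher number from compound 1 to compound 2 (0.29 log units; within the scatter), also stays within the scatter. Going by the values given here, no ethoxy compound has been measured yet, and the data give no firm direction. No step beyond the scatter is therefore expected in this assay. The expected step is a 1.2-fold lower number from compound 3 to compound 4 (0.07 log units; within the scatter). For compound 4 the estimated value is 5.5 ug/mL, with an expected range of 2.8 ug/mL to 11 ug/mL.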

Compound 4, half-maximal inhibitory concentration: 6.4 ug/mL
Compound 4: middle estimate off by 1.2-fold (0.07 log units), on the low side; low and high end bracket the measured number.
By their numbers in this assay, from the lowest: compounds 1, 4, 3 and 2 (each within the scatter of the next).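

In this assay, ethoxy in place of bromo on the aromatic carbon, para to a large group, gives a 1.0-fold lower number from compound 3 to compound 4 (0.01 log units; within the scatter) and so leaves the number essentially where it stood, which adds an alkoxy group with a short chain to a position that had so far shown only butoxy, hexyloxy and bromo. The two chain comparisons that compound 4 makes possible, a 1.6-fold lower number from compound 2 to compound 4 (0.21 log units; within the scatter) and a 1.2-fold higher number from compound 1 to compound 4 (0.08 log units; within the scatter), also stay within the scatter, so ethoxy, butoxy and hexyloxy at this place are not separated and compounds 1, 2 and 4 give no reliable trend with chain length. No measurement on these compounds accounts for this lack of separation, and no explanation for it can be offered from the present data.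

Going by these compounds, all four groups at this position fall within the scatter of one another, so it remains open whether this position can move the number at all. A hydroxy group, an amine or a carboxylic acid in place of ethoxy, or a chain longer than hexyloxy, would test this more sharply than further small alkoxy changes.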